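Step from compound 1 to compound 3

This account rests on a few compounds, and the source may have more. Where it says the series, first, only, none or still open, it means among the compounds named here.

Compound 1 `CC(=O)c1ccc(NC(=O)Nc2cc(C)nc3ccccc23)cc1` gives the highest of the two numbers in an ADME assay for permeability, using PAMPA, at pH 7.4 (a lower number here means that the compound crosses the layer more slowly, a higher number that the compound crosses the layer faster), with 473 10^-6 cm/s. Compound 2 `Cc1cc(NC(=O)Nc2cnc3ccccc3c2)c2ccccc2n1`, the nearest, gives 46 10^-6 cm/s in this assay, a gap beyond the usual scatter. Compound 3 `Cc1cc(NC(=O)Nc2ccc(SC(F)(F)F)cc2)c2ccccc2n1` is not yet measured. It differs from compound 1 by (trifluoromethyl)sulfanyl in place of acetyl on an aromatic carbon. Among the compounds with values here, no measured pair shows this kind of change, so the expected step of a 1.2-fold higher number from compound 1 to compound 3 (0.07 log units; within the scatter) is small, within the scatter or a slight rise. Compound 3 is therefore expected to give 550 10^-6 cm/s in this assay, within a range from 250 10^-6 cm/s to 1100 10^-6 cm/s.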

Compound 3, apparent permeability: 206 10^-6 cm/s
Compound 3: the middle estimate sits 2.7-fold (0.43 log units) above what was measured; the whole stated range lies above it.
By their numbers in this assay, from the lowest: compound 2; then compound 3; then compound 1.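

Within the data shown here, at this aromatic carbon, para to a large group, the choice of group matters in this assay: (trifluoromethyl)sulfanyl in place of acetyl gives a 2.3-fold lower number from compound 1 to compound 3 (0.36 log units; beyond the scatter) as the first single-place step. Both groups count as one hydrogen-bond acceptor with no net charge, so those counts do not separate compound 1 from compound 3. No measurement shown here accounts for the step. On these data alone, whether the same change gives a similar step on another core stays open. So does the effect of an amine or a carboxylic acid at this carbon.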